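Opening the ring amine of compound 3: a smaller side chain

The compounds below may be only part of what the source reports. "The series", "measured", "known", "first", "only" and "open" are said of these compounds alone.

Of the compounds shown here, three sharing one core have been tested in an assay on isolated protein for binding affinity to 5-hydroxytryptamine receptor 1B (Homo sapiens); a higher number here means a weaker inhibitor, a lower number a stronger inhibitor. Compound 1 `CCCN(CCC)Cc1ccc(Cl)c(-c2ccccc2OC)c1` carries a dipropylaminomethyl chain; in this assay compound 1 reaches only the limit of > 10000 nM, which is a boundary of the assay rather than a number, as noted in the limit of > 10000 nM in this assay, at which 1 of the 3 values shown sits. Compound 2 `COc1ccccc1-c1cc(C2CCNC2)ccc1Cl` gives 410 nM, and compound 3 `COc1ccccc1-c1cc(C2CCN(C)C2)ccc1Cl` gives 12 nM. Compound 3 thus stands at the lowest of the two numbers that were obtained, and the step of a 34-fold lower number from compound 2 to compound 3 (1.53 log units; beyond the scatter) shows how much a methyl on the ring nitrogen matters.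

Compound 4 `CNCc1ccc(Cl)c(-c2ccccc2OC)c1` has not yet been measured. Its change from compound 3 is (methylamino)methyl in place of 1-methylpyrrolidin-3-yl on an aromatic carbon. Going by the values given here, no measured step covers exactly this change; the closest hints are that compound 1 with an open-chain amine sits at a limit, and that removing the methyl from the nitrogen in compound 2 costs a large amount. Compound 4 keeps a methyl on the nitrogen but loses the ring, so a weakening step is expected in this assay, a 25-fold higher number from compound 3 to compound 4 (1.40 log units; beyond the scatter). For compound 4 the estimate in this assay is 300 nM, with a range from 60 nM to 3000 nM.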

Compound 4, inhibition constant: 1200 nM
The estimate for compound 4 lay 4.0-fold (0.60 log units) below the measured number; the range from low to high includes it.
By their numbers in this assay, from the lowest: compound 3; then compound 2; then compound 4. At a limit, above all of these: compound 1.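

In this assay, replacing 1-methylpyrrolidin-3-yl with the open (methylamino)methyl group gives a 100-fold higher number from compound 3 to compound 4 (2.00 log units; beyond the scatter), so a methyl on the nitrogen does not preserve the low number of compound 3 once the ring is gone. Measured against the ring that lacks this methyl, the open chain gives a 2.9-fold higher number from compound 2 to compound 4 (0.47 log units; beyond the scatter), a modest step, so both ring compounds have lower numbers than the open-chain compound 4. With methylamino in place of dipropylamino, the step is an at least 8.3-fold lower number from compound 1 to compound 4 (0.92 log units; beyond the scatter), and it starts from a limit, not a number: the limit of > 10000 nM in this assay, at which 1 of the 4 values shown sits.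

On these data alone, it remains open whether the open chain falls short for lack of the ring or for lack of a second group on its nitrogen. A dimethylaminomethyl chain or a piperidine ring at this position could help separate these two readings.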